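Oxindole thiosemicarbazones on HCT-116: a nitrophenyl piperazine variant

The source may report more compounds than this note shows. Statements on the series, on what has been measured and on what is new or still open speak of the compounds shown alone.

Measured so far:
compound 1, `O=C1Nc2cccc(Br)c2/C1=N/NC(=S)N1CCN(c2ccccc2)CC1`: 33600 nM
compound 2, `COc1ccc(N2CCN(C(=S)N/N=C3\C(=O)Nc4ccc(Cl)cc43)CC2)cc1`: 7740 nM

In a functional assay on HCT-116 cells (Homo sapiens) for inhibition, read by MTT assay, with a stated time of 72 h (on this read-out lower numbers stand for stronger inhibition and higher numbers for weaker inhibition), compound 1 gives 33600 nM and compound 2 gives 7740 nM. Compound 2 holds the lower of the two numbers, and the gap to compound 1 is beyond the usual scatter, so compound 2 stands as the stronger inhibitor of the pair. The two compounds differ in more than one place, so the gap cannot be assigned to any single change.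

Compound 3, `O=C1Nc2ccc(Cl)cc2/C1=N/NC(=S)N1CCN(c2ccccc2[N+](=O)[O-])CC1`, keeps the core of compound 2 and alters only the aryl group on the piperazine: 2-nitrophenyl in place of 4-methoxyphenyl on an amine nitrogen in a ring. For the measured compounds named here, no measured pair in this assay isolates a change of this kind, so there is no step on which to anchor a direction. The expectation is a step from compound 2 to compound 3 that is small, probably not beyond the scatter, with either sign possible; the estimated step is a 1.3-fold higher number from compound 2 to compound 3 (0.11 log units; within the scatter). On that basis, compound 3 is expected to give about 10000 nM, within a range of 3000 nM to 35000 nM.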

Compound 3, half-maximal inhibitory concentration: 4570 nM
The estimate for compound 3 lay 2.2-fold (0.34 log units) above the measured number; the range from low to high includes it.
By their numbers in this assay, from the lowest: compounds 3 and 2 (each within the scatter of the next); then compound 1.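

In this assay, for the compounds shown here, putting 2-nitrophenyl in place of 4-methoxyphenyl on an amine nitrogen in a ring gives a 1.7-fold lower number from compound 2 to compound 3 (0.23 log units; within the scatter) and is the first step that isolates this position. On this read-out the two aryl groups cannot be told apart, even though the entering group has one more heavy atom and one more hydrogen-bond acceptor, so this position accepts at least this one exchange of aryl groups without a change beyond the scatter. No measured property of either group is available to bear on this result.

The compounds shown leave open whether the piperazine nitrogen keeps this tolerance when the aryl group gives way to something of a different kind, such as a benzyl group, a pyridine ring or a short alkyl chain ending in an amine or a carboxylic acid. Compound 1 differs from compound 2 and compound 3 in more than one place, so the steps to it cannot be read, and the separate roles of the bromine and chlorine on the core and of the substituent on the phenyl ring remain unresolved.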